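Cyano for methoxy on a shared core tested for binding to 17-beta-hydroxysteroid dehydrogenase type 1

The source may hold more compounds than are shown below. What is called first, only, known or untested is meant among the compounds shown, and "the series" means these compounds.

Measured compounds:
- compound 1, `Oc1cccc2cc(-c3ccccc3)ccc12`: < 10%
- compound 2, `COc1ccc(-c2ccc3c(O)cccc3c2)cc1`: 28%

Of the compounds shown here, two sharing one core have been measured in an assay for binding affinity to 17-beta-hydroxysteroid dehydrogenase type 1 (Homo sapiens), with a stated time of 20 min, tested at 1 uM; on this read-out higher numbers stand for more inhibition at the one concentration tested (going by the name of the read-out) and lower numbers for less inhibition. Compound 1, `Oc1cccc2cc(-c3ccccc3)ccc12`, sits at the limit of this assay with < 10%, which is a limit rather than a number (the limit of < 10% in this assay, at which 1 of the 2 values shown sits). Compound 2, `COc1ccc(-c2ccc3c(O)cccc3c2)cc1`, gives 28%, the only number shown. For the measured compounds named here, the one step measured, a number at least 18 percentage points higher from compound 1 to compound 2 (beyond the scatter), is methoxy in place of hydrogen on an aromatic carbon.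

Compound 3, `N#Cc1ccc(-c2ccc3c(O)cccc3c2)cc1`, is not yet measured. It differs from compound 2 by cyano in place of methoxy on an aromatic carbon. Going by the values given here, no measured step exchanges one group for another at this carbon; the step from compound 1 to compound 2 shows only that adding methoxy there raised the read-out, so it bears on the new step only indirectly. In this assay compound 3 is therefore expected to stay near compound 2, with the step from compound 2 to compound 3 estimated as a number 2 percentage points higher from compound 2 to compound 3 (within the scatter), a step within the scatter. The estimated value for compound 3 is 30%, expected between 10% and 55%.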

Compound 3, a percentage reported as inhibition, at one concentration (the size of the read-out at that concentration, not a potency): 16%
Estimate against measurement, compound 3: 14 percentage points above; low and high end bracket the measured number.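

In this assay, the aromatic carbon para to a large group proves sensitive to which group it carries, not only to whether it carries one: a number 12 percentage points lower from compound 2 to compound 3 (beyond the scatter). For the compounds shown here, this exchange is the first measured between two groups at this carbon, and it separates methoxy from cyano even though the two have the same heavy-atom and hydrogen-bond acceptor counts. Cyano in place of hydrogen gives a much less clear result, a number at least 6 percentage points higher from compound 1 to compound 3 (that floor lies within the scatter), and compound 1 gives < 10%, which is a limit rather than a number, so the true size of this step cannot be read: the limit of < 10% in this assay, at which 1 of the 3 values shown sits.

The compounds shown leave open whether methoxy is unusual at this carbon or whether other groups, such as an amine, a carboxylic acid, a chlorine atom or a longer chain like ethoxy, would give a read-out nearer that of compound 2 or that of compound 3. They also leave open whether the difference between methoxy and cyano would persist if either group were moved elsewhere on that ring.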